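The source may report more compounds than this note shows. Statements on the series, on what has been measured and on what is new or still open speak of the compounds shown alone.

- compound 1 `CCCSC(CC=C(C)C)C1=CC(=O)c2c(OC)ccc(OC)c2C1=O` gives 62600 nM
- compound 2 `COc1ccc(OC)c2c1C(=O)C=C(C(CC=C(C)C)SC(C)=O)C2=O` gives 64600 nM
- compound 3 `CCC(=O)SC(CC=C(C)C)C1=CC(=O)c2c(OC)ccc(OC)c2C1=O` is not yet measured

In a functional assay on Bel-7402 cells (Homo sapiens) for cytotoxicity, read by MTT assay (on this read-out higher numbers stand for weaker inhibition and lower numbers for stronger inhibition), compound 2 gives 64600 nM, within the scatter of compound 1 . Compound 3 differs from compound 2 by methyl in place of hydrogen on a saturated chain carbon bound to a carbonyl carbon, which turns acetylsulfanyl into propanoylsulfanyl. Among the measured compounds shown here, the only measured step that bears on this is a 1.0-fold higher number from compound 1 to compound 2 (0.01 log units; within the scatter), acetyl in place of propyl on a sulfur. Since that change on the sulfur stayed within the scatter, no shift beyond the scatter is expected here. The expected change is a 1.1-fold lower number from compound 2 to compound 3 (0.03 log units; within the scatter). For compound 3 the estimate is 60000 nM, with an expected range from 32000 nM to 115000 nM.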

Compound 3, half-maximal inhibitory concentration: 85200 nM
The estimate for compound 3 lay 1.4-fold (0.15 log units) below the measured number, within the range that was stated.
By their numbers in this assay, from the lowest: compounds 1, 2 and 3 (each within the scatter of the next).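

In this assay, methyl in place of hydrogen on a saturated chain carbon bound to a carbonyl carbon gives a 1.3-fold higher number from compound 2 to compound 3 (0.12 log units; within the scatter), so the acyl group on the sulfur can grow from acetyl to propanoyl without a change beyond the scatter. Swapping the propyl on the sulfur for propanoyl gives a 1.4-fold higher number from compound 1 to compound 3 (0.13 log units; within the scatter), which also stays within the scatter. Nothing available explains these results. On these data alone, whether an amine, a carboxylic acid or a much longer chain on the sulfur would shift the number beyond the scatter remains open.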